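Swapping one benzyl group for another on the thioether

A few compounds are considered here, and "the series" means these few. Any claim that something is new, unique, unknown or untested is made for them only; others in the source may bear on it.

Of the compounds shown here, two built on a shared core have been measured in a functional assay on MCF7 cells (Homo sapiens) for cytotoxicity, read by MTT assay, with a stated time of 24 h; on this read-out higher numbers stand for weaker inhibition and lower numbers for stronger inhibition. Compound 1, `Cn1nc(-c2nnc(S)o2)cc1-c1ccc(C(F)(F)F)cc1`, gives in this assay only a limit, > 100000 nM. Compound 2, `Cn1nc(-c2nnc(SCc3ccc(C(F)(F)F)cc3)o2)cc1-c1ccc(C(F)(F)F)cc1`, gives in this assay 15500 nM. This is the only number shown, while the other value sits at the limit (the limit of > 100000 nM in this assay, at which 1 of the 2 values shown sits). For the measured compounds named here, the single measured step, an at least 6.4-fold lower number from compound 1 to compound 2 (0.80 log units; beyond the scatter), attaches a whole benzyl group to the sulfur.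

Compound 3, `Cn1nc(-c2nnc(SCc3ccc(Cl)cc3F)o2)cc1-c1ccc(C(F)(F)F)cc1`, differs from compound 2 by 4-chloro-2-fluorophenyl in place of 4-(trifluoromethyl)phenyl on a saturated chain carbon bound to a sulfur. Going by the values given here, no measured step concerns an exchange of one benzyl group for another: the step of an at least 6.4-fold lower number from compound 1 to compound 2 (0.80 log units; beyond the scatter) tells only that the benzyl group itself matters, not which substituents it carries. Among the compounds with values here, no step in this assay beyond the usual scatter is therefore expected from compound 2 to compound 3, and the expected step of a 1.0-fold lower number from compound 2 to compound 3 (0.01 log units; within the scatter) reflects that. In this assay compound 3 is estimated at 15000 nM, with a range from 5000 nM to 50000 nM.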

Compound 3, half-maximal inhibitory concentration: 18200 nM
Compound 3: middle estimate off by 1.2-fold (0.08 log units), on the low side, within the range that was stated.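

In this assay, replacing the 4-(trifluoromethyl)phenyl, with 10 heavy atoms, by the 4-chloro-2-fluorophenyl, with 8, on the saturated chain carbon bound to the sulfur gives a 1.2-fold higher number from compound 2 to compound 3 (0.07 log units; within the scatter), so these two benzyl groups cannot be told apart here despite their different substituents. The comparison with hydrogen on the sulfur now holds for a second benzyl group, at an at least 5.4-fold lower number from compound 1 to compound 3 (0.73 log units; beyond the scatter), and the earlier finding therefore no longer rests on compound 2 alone. This second step, like the first, can be read only as a lower bound, as its starting value is a limit and not a number: the limit of > 100000 nM in this assay, at which 1 of the 3 values shown sits.

The two benzyl groups shown both carry halogen substituents, so it stays open how an unsubstituted benzyl, a benzyl bearing a methoxy group or a carboxylic acid, or a plain hexyl chain on the sulfur would read. Also open, as far as these compounds go, is how this assay would respond to an amine nitrogen in place of the sulfur, or to an exchange of the 4-(trifluoromethyl)phenyl on the shared core.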